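This account rests on a few compounds, and the source may have more. Where it says the series, first, only, none or still open, it means among the compounds named here.

Measured compounds:
compound 1, `O=C1Nc2ccccc2[C@]12N[C@H](c1ccccc1)[C@H](c1ccccc1)[C@@]21CCc2c([nH]c3ccc(Cl)cc23)C1=O`, 15000 nM
compound 2, `O=C1Nc2ccccc2[C@]12N[C@H](c1ccccc1)[C@H](c1cccs1)[C@@]21CCc2c([nH]c3ccc(Cl)cc23)C1=O`, 14000 nM
compound 3, `COc1ccc([C@H]2[C@@H](c3ccccc3)N[C@@]3(C(=O)Nc4ccccc43)[C@]23CCc2c([nH]c4ccc(C)cc24)C3=O)cc1`, 20000 nM

In a functional assay on A549 cells (Homo sapiens) for antiproliferative activity, read by MTT assay, with a stated time of 48 h (a lower number here means a stronger inhibitor, a higher number a weaker inhibitor), compound 3 gives the highest of the three numbers, yet its gaps to compound 1 and to compound 2 both lie within the scatter, so the three measured compounds cannot be told apart. Among the compounds with values here, the one measured step, a 1.1-fold lower number from compound 1 to compound 2 (0.03 log units; within the scatter), concerns a different part of the shared core and does not bear on the change at hand. Compound 4, `COc1ccc([C@H]2[C@@H](c3ccccc3)N[C@@]3(C(=O)Nc4ccccc43)[C@]23CCc2c([nH]c4ccc(Cl)cc24)C3=O)cc1`, differs from compound 3 by chloro in place of methyl on an aromatic carbon. Within the data shown here, no measured pair isolates this exchange; compound 1 carries the chloro group, compound 3 the methyl, but they differ elsewhere too, and their values sit within the scatter of each other. Compound 4 is therefore expected to show a step of a 1.3-fold lower number from compound 3 to compound 4 (0.12 log units; within the scatter), nothing beyond the scatter, with an estimated value of 15000 nM between 7000 nM and 30000 nM.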

Compound 4, half-maximal inhibitory concentration: 18000 nM
Compound 4: the middle estimate sits 1.2-fold (0.08 log units) below what was measured; measured number inside the range.
By their numbers in this assay, from the lowest: compounds 2, 1, 4 and 3 (each within the scatter of the next).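

In this assay, the exchange of methyl for chloro on this aromatic carbon is now isolated, and the step, a 1.1-fold lower number from compound 3 to compound 4 (0.05 log units; within the scatter), shows that this exchange alone does not move the number beyond the scatter. The two other single changes read the same way: a 1.3-fold higher number from compound 2 to compound 4 (0.11 log units; within the scatter) at the saturated ring carbon, and a 1.2-fold higher number from compound 1 to compound 4 (0.08 log units; within the scatter) with the added methoxy. No evidence is available to explain these results.

On these data alone, it remains open whether an amine or a carboxylic acid on this aromatic carbon would give a step beyond the scatter.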